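This account rests on a few compounds, and the source may have more. Where it says the series, first, only, none or still open, it means among the compounds named here.

Measured so far in an ADME assay on Vero cells (Chlorocebus sabaeus) for cytotoxicity, with a stated time of 5 days; on this read-out lower numbers stand for stronger inhibition and higher numbers for weaker inhibition:
- compound 1, `[N-]=[N+]=N[C@H]1C[C@H](n2cnc3c(NCCO)nc(N)nc32)O[C@@H]1CO`: compound 1 gives > 100000 nM, a limit of this assay
- compound 2, `CN(C)c1nc(Cl)nc2c1ncn2[C@H]1C[C@H](N=[N+]=[N-])[C@@H](CO)O1`: compound 2 gives > 100000 nM, a limit of this assay
- compound 3, `[N-]=[N+]=N[C@H]1C[C@H](n2cnc3c(NC4CC4)nc(Cl)nc32)O[C@@H]1CO`: compound 3 gives > 100000 nM, a limit of this assay

Compound 1 stands only at a limit in this assay, with no number behind it. Among the measured compounds shown here, all three values sit at the limit of > 100000 nM in this assay, at which 3 of the 3 values shown sit, so no compound can be set above or below another. For the measured compounds named here, the one step between compounds that differ in a single place, cyclopropylamino in place of dimethylamino on an aromatic carbon, is a step that the two limits leave unreadable from compound 2 to compound 3, and so it carries no readable size.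

Compound 4, `CC(CO)Nc1nc(N)nc2c1ncn2[C@H]1C[C@H](N=[N+]=[N-])[C@@H](CO)O1`, is not yet measured. It differs from compound 1 by methyl in place of hydrogen on a saturated chain carbon bound to a nitrogen on an aromatic ring and a saturated chain carbon. Going by the values given here, no measured step covers this change, and the only measured step is itself unreadable, so the expectation for compound 4 rests on the limit of compound 1 alone. The step from compound 1 to compound 4 is therefore expected to be a step that the limit leaves unreadable from compound 1 to compound 4, that is, none beyond the scatter, and most likely another limit. Compound 4 is expected at about 150000 nM, with a range from 80000 nM to 300000 nM.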

Compound 4, half-maximal inhibitory concentration: > 100000 nM
Compound 4: only a limit was reported (the forecaster's own chance of this, stated with the estimate: 90%); the middle value is on the limit's open side.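

Compound 4 stands at a limit in this assay, as compound 1 does, so the step from compound 1 to compound 4 cannot be read: the limit of > 100000 nM in this assay, at which 4 of the 4 values shown sit.

The compounds shown leave open where any of them would reach half-maximal inhibition in this assay, and whether methyl in place of hydrogen alters that value.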